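Amino to aminomethyl on the amide side chain

The compounds below may be only part of what the source reports. "The series", "measured", "known", "first", "only" and "open" are said of these compounds alone.

Three compounds carry numbers in a functional assay on CHO cells with Melanocortin receptor 4 (Homo sapiens) as the target, read by cAMP accumulation; a lower number here means a smaller maximal response, a higher number a larger maximal response. Compound 1 `CCC(=O)N1C[C@@H](C(=O)N2CCN(c3ccc(C)cc3[C@@H](NC(=O)CCN(C)C)C(C)C)CC2)[C@H](c2ccc(Cl)cc2)C1` gives 129%; compound 2 `Cc1ccc(N2CCN(C(=O)[C@@H]3CN(C4CCOCC4)C[C@H]3c3ccc(Cl)cc3)CC2)c([C@@H](NC(=O)CN)C(C)C)c1` gives 114%; compound 3 `CC(C)[C@H](NC(=O)CCN(C)C)c1cccc(F)c1N1CCN(C(=O)[C@@H]2CN(C(C)C)C[C@H]2c2ccc(C(F)(F)F)c(F)c2)CC1` gives 47%. Compound 2 thus stands second highest of the three: compound 1 is nearest, higher by a gap beyond the usual scatter, and compound 3 is furthest, lower by a gap far beyond it. Among the compounds with values here, no two measured compounds differ in a single place, so no measured step anchors the change considered next.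

Compound 4 `Cc1ccc(N2CCN(C(=O)[C@@H]3CN(C4CCOCC4)C[C@H]3c3ccc(Cl)cc3)CC2)c([C@@H](NC(=O)CCN)C(C)C)c1` has not been measured. It differs from compound 2 by aminomethyl in place of amino on a saturated chain carbon bound to a carbonyl carbon. The shared core and the remaining substituents are unchanged. Compound 1, whose amide bears a longer chain ending in an amine, gives 129%, so a longer amide chain does not depress the maximal response in this assay. The step of a number 4 percentage points higher from compound 2 to compound 4 (within the scatter) is therefore expected to be small, if anything upward, and within the usual scatter. For compound 4 the expected value in this assay is 118%, with a range of 100% to 136%.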

Compound 4, intrinsic activity: the largest response reached, in percent of the reference agonist's: 107%
The estimate for compound 4 lay 11 percentage points above the measured number, and the stated range covers the measured number.
By their numbers in this assay, from the lowest: compound 3; then compounds 4 and 2 (each within the scatter of the next); then compound 1.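

Aminomethyl in place of amino, on a saturated chain carbon bound to a carbonyl carbon, gives the only one-place comparison in the series: in this assay the step is a number 7 percentage points lower from compound 2 to compound 4 (within the scatter). With the shared core and the other substituents fixed, the maximal response therefore does not separate the 2-aminoethyl chain from the aminomethyl chain on this amide. No accompanying measurement bears on this result, so the step stays a bare observation.

On these data alone, whether a carboxylic acid in place of the terminal amine, or a 3-aminopropyl chain, would hold the response at this position stays open. The dimethylamino chain end of compound 1 cannot be read at this position, as compound 1 differs from compound 4 in more than one place.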